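The source may report more compounds than this note shows. Statements on the series, on what has been measured and on what is new or still open speak of the compounds shown alone.

Within the data shown here, in a functional assay on K562 cells (Homo sapiens) for antiproliferative activity, read by CCK-8 assay, with a stated time of 72 h (on this read-out higher numbers stand for weaker inhibition of growth and lower numbers for stronger inhibition of growth), there are three measured compounds so far, and they differ from one another in more than one place. Compound 1 `CCC1C(=O)N(C)c2cnc(Nc3ccc(S(=O)(=O)NC)cc3)nc2N1c1ccn(C)n1` stands at 2890 nM and compound 3 `CC[C@@H]1C(=O)N(C)c2cnc(Nc3ccc(S(=O)(=O)NC)cc3)nc2N1C1CCCC1` at 222 nM on this scale. Compound 2 `CCC1C(=O)N(C)c2cnc(-n3ccc4cc(C(=O)NC(C)C)ccc43)nc2N1c1ccn(C)n1` has the highest number of the three at 8910 nM as its reading, and its gaps to both others lie beyond the scatter. Among the measured compounds shown here, it is therefore the weakest growth inhibitor measured so far.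

For the measured compounds named here, the next compound is compound 4 `CCC1C(=O)N(C)c2cnc(-n3ccc4cc(C(=O)NC)ccc43)nc2N1c1ccn(C)n1`, which differs from compound 2 by methyl in place of isopropyl on an amide-type nitrogen as its only change: methyl in place of isopropyl on an amide-type nitrogen. The rest of the structure stays the same. Going by the values given here, no measured pair isolates a change at this place, so the data offer no direct guide to its size or direction. The working expectation in this assay is therefore no change beyond the scatter, with only a slight lean towards a lower number. The estimated move is a 1.3-fold lower number from compound 2 to compound 4 (0.10 log units; within the scatter) and would stay within that scatter. A reading reported only as a limit remains possible at this end of the scale. For compound 4 the expected value is 7000 nM as the middle estimate, with an expected range from 2500 nM to 20000 nM for the coming measurement.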

Compound 4, concentration for 50% growth inhibition: 13300 nM
For compound 4 the middle estimate is 1.9-fold (0.28 log units) below the measured one; the measured number falls inside the stated range.
By their numbers in this assay, from the lowest: compound 3; then compound 1; then compounds 2 and 4 (each within the scatter of the next).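

Methyl in place of isopropyl on an amide-type nitrogen is the first change in this series that can be read on its own, and in this assay it gives a 1.5-fold higher number from compound 2 to compound 4 (0.17 log units; within the scatter). At this place, the read-out therefore does not separate isopropyl from methyl, and this single pair sets no direction for the change. The finding applies only to the background shared by this pair, and no available measurement offers an explanation for the result.

As far as these compounds go, it remains open whether a different group on this nitrogen, such as a cyclopropyl ring, a longer chain or a terminal amine, or the unsubstituted carboxamide, would give a step beyond the scatter. Among these compounds, also open is whether the same exchange of isopropyl for methyl would read alike on a compound carrying a different group on the core in place of the one shared by this pair.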